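From compound 2 to compound 3: changing the aryl ketone group

The source may report more compounds than this note shows. Statements on the series, on what has been measured and on what is new or still open speak of the compounds shown alone.

In a functional assay on MIA PaCa-2 cells (Homo sapiens) for antiproliferative activity, read by sulforhodamine B assay, with a stated time of 48 h (a lower number here means a stronger inhibitor, a higher number a weaker inhibitor), compound 1 (`COc1cc(OC)c2sc(-c3ccc(N/C=C\C(=O)c4cc(OC)c(OC)c(OC)c4)c(C)c3)nc2c1`) gives 17000 nM and compound 2 (`COc1cc(OC)c2sc(-c3ccc(N/C=C\C(=O)c4cc(OC)c(OC)c(OC)c4)cc3)nc2c1`) gives 26800 nM. For the measured compounds named here, these are the only two numbers so far, and compound 2 stands within the scatter of compound 1.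

The next compound is compound 3 (`COc1cc(OC)c2sc(-c3ccc(N/C=C\C(=O)c4ccc(OC)c(F)c4)cc3)nc2c1`), which differs from compound 2 on a carbonyl carbon: 3-fluoro-4-methoxyphenyl in place of 3,4,5-trimethoxyphenyl on a carbonyl carbon. In short, 3-fluoro-4-methoxyphenyl takes the place of 3,4,5-trimethoxyphenyl.

Going by the values given here, the single measured step is a 1.6-fold higher number from compound 1 to compound 2 (0.20 log units; within the scatter). It is hydrogen in place of methyl on an aromatic carbon, so it concerns a different place in the structure and bears on this change only indirectly. Among the compounds with values here, no measured pair varies the group on the carbonyl carbon, and the data therefore give no direction.

No step beyond the scatter is expected in this assay, although the uncertainty is wide. The expected step is a 1.1-fold lower number from compound 2 to compound 3 (0.03 log units; within the scatter). For compound 3 the estimated value is 25000 nM, with an expected range of 8000 nM to 80000 nM.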

Compound 3, half-maximal inhibitory concentration: 4300 nM
Estimate against measurement, compound 3: 5.8-fold (0.76 log units) above; the measured number lies below the stated range.
By their numbers in this assay, from the lowest: compound 3; then compounds 1 and 2 (each within the scatter of the next).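

For the compounds shown here, the carbonyl carbon is the first place where a single change moves the number beyond the scatter in this assay: a 6.2-fold lower number from compound 2 to compound 3 (0.79 log units; beyond the scatter), whereas the change on the aromatic carbon stays within it at a 1.6-fold higher number from compound 1 to compound 2 (0.20 log units; within the scatter). The 3,4,5-trimethoxyphenyl group is therefore not needed for antiproliferative activity in this pair, and 3-fluoro-4-methoxyphenyl gives the lower number despite having fewer heavy atoms and fewer hydrogen-bond acceptors. Nothing measured here accounts for the drop in the number.

This single swap both adds a fluorine and changes the methoxy groups, so compound 2 and compound 3 alone cannot show which of these alterations goes with the lower number. Also open, going by these compounds, is how the number responds with an unsubstituted phenyl on the carbonyl carbon, or with a hydroxyl, an amine or a chlorine on that aryl ring, and whether the methyl on the aromatic carbon still stays within the scatter when paired with 3-fluoro-4-methoxyphenyl.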